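Swapping Ethyl for Amino on the Glycine Chain

The source may hold more compounds than are shown below. What is called first, only, known or untested is meant among the compounds shown, and "the series" means these compounds.

Three compounds sharing the core of compound 3 `CCCC(=O)NCC(=O)N(C)c1ccc(Cl)cc1C(=O)c1ccccc1Cl` have been tested in a functional assay on the whole organism for antagonist activity, with Mus musculus as the target; on this read-out lower numbers stand for an effect already at smaller amounts and higher numbers for an effect only at larger amounts of compound. Compound 3 gives 0.98 mg/kg, which places it second highest of the three numbers. Compound 2 `CC(NC(=O)CN)C(=O)N(C)c1ccc(Cl)cc1C(=O)c1ccccc1Cl` gives 0.47 mg/kg, and the step of a 2.1-fold higher number from compound 2 to compound 3 (0.32 log units; beyond the scatter) lies beyond the scatter. Compound 1 `CN(C)CC(=O)NCC(=O)N(C)c1ccc(Cl)cc1C(=O)c1ccccc1Cl` gives 2.6 mg/kg; the steps of a 2.7-fold lower number from compound 1 to compound 3 (0.42 log units; beyond the scatter) and a 5.5-fold lower number from compound 1 to compound 2 (0.74 log units; beyond the scatter) are both modest yet beyond the scatter.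

Compound 4 `CN(C(=O)CNC(=O)CN)c1ccc(Cl)cc1C(=O)c1ccccc1Cl` has not yet been measured. Its change from compound 3 is amino in place of ethyl on a saturated chain carbon bound to a carbonyl carbon. The step that bears most directly on this is a 2.7-fold lower number from compound 1 to compound 3 (0.42 log units; beyond the scatter), where the group on that same chain carbon was also exchanged and the number fell. Compound 2, whose chain likewise ends in ((aminomethyl)carbonyl)amino, gave the lowest number of the three. A modest step toward a lower number is therefore expected, namely a 1.4-fold lower number from compound 3 to compound 4 (0.15 log units; within the scatter). Compound 4 is estimated at 0.7 mg/kg, with a range from 0.3 mg/kg to 1.6 mg/kg.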

Compound 4, dose for half-maximal effect: 0.58 mg/kg
The estimate for compound 4 lay 1.2-fold (0.08 log units) above the measured number; measured number inside the range.
By their numbers in this assay, from the lowest: compounds 2, 4 and 3 (each within the scatter of the next, the first and the last beyond it); then compound 1.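

In this assay, amino in place of ethyl on a saturated chain carbon bound to a carbonyl carbon gives a 1.7-fold lower number from compound 3 to compound 4 (0.23 log units; within the scatter), so this exchange cannot be told apart from no change. On that same carbon, amino in place of dimethylamino gives a 4.5-fold lower number from compound 1 to compound 4 (0.65 log units; beyond the scatter), which shows that the two nitrogen groups are not interchangeable here. Hydrogen in place of methyl on the chain carbon bound to an amide-type nitrogen and a carbonyl carbon gives a 1.2-fold higher number from compound 2 to compound 4 (0.09 log units; within the scatter), so the low number of compound 2 does not depend on that methyl.

Nothing available explains these differences. Still open, from the compounds shown here alone, is how a methylamino group, a hydroxy group or a longer aminoethyl chain would read on the same carbon.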